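Moving a Hydroxyl Group: a Repeated Change, a Likely Limit

The source may hold more compounds than are shown below. What is called first, only, known or untested is meant among the compounds shown, and "the series" means these compounds.

Measured so far:
compound 1 `Oc1cccc(-c2cc(-c3cccc(OC(F)(F)F)c3)cc(-c3ccccc3O)n2)c1`: 5390 nM
compound 2 `Oc1ccc(-c2cc(-c3cccc(OC(F)(F)F)c3)cc(-c3ccccc3O)n2)cc1`: > 50000 nM
compound 3 `Oc1ccc(-c2cc(-c3cccc(OC(F)(F)F)c3)cc(-c3cccc(O)c3)n2)cc1`: 5040 nM

Of the compounds shown here, three have been tested in a functional assay on T47D cells (Homo sapiens) for inhibition; a higher number here means a weaker inhibitor, a lower number a stronger inhibitor. Compound 1 gives 5390 nM and compound 3 gives 5040 nM. For compound 2 the value > 50000 nM is a limit of the assay, not a number. Compounds 1 and 3 differ by 4-hydroxyphenyl in place of 2-hydroxyphenyl on an aromatic carbon, which made a 1.1-fold lower number from compound 1 to compound 3 (0.03 log units; within the scatter). Compound 1 differs from compound 2 by 4-hydroxyphenyl in place of 3-hydroxyphenyl on an aromatic carbon, which made an at least 9.2-fold higher number from compound 1 to compound 2 (0.96 log units; beyond the scatter), a step that rests on (the limit of > 50000 nM in this assay, at which 1 of the 3 values shown sits). Compound 4 `Oc1ccc(-c2cc(-c3cccc(OC(F)(F)F)c3)cc(-c3ccc(O)cc3)n2)cc1` has not been measured; it differs from compound 3 by 4-hydroxyphenyl in place of 3-hydroxyphenyl on an aromatic carbon. This is the same kind of change as before, though not the same: here the place is meta to a 3-hydroxyphenyl group rather than meta to a 2-hydroxyphenyl group. The expectation rests on the step of an at least 9.2-fold higher number from compound 1 to compound 2 (0.96 log units; beyond the scatter). Compound 4 is therefore expected to show a 9.9-fold higher number from compound 3 to compound 4 (1.00 log units; beyond the scatter). Compound 4 is estimated at 50000 nM, and the assay may again report only a limit.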

Compound 4, half-maximal inhibitory concentration: > 50000 nM
Compound 4 ended at the assay's limit; the forecaster's own chance of this, stated with the estimate: 60%; the middle value lies on the limit itself.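

In this assay, putting 4-hydroxyphenyl in place of 3-hydroxyphenyl again raised the number, giving an at least 9.9-fold higher number from compound 3 to compound 4 (0.99 log units; beyond the scatter) on the core of compound 3. The change therefore pushed the same way on both cores shown, but two cores do not make a rule for the series, and its exact size on either core remains unknown: the same change on two cores in this assay, an at least 9.2-fold higher number (0.96 log units; beyond the scatter) from compound 1 to compound 2 and an at least 9.9-fold higher number (0.99 log units; beyond the scatter) from compound 3 to compound 4; the limit leaves it open whether they differ
The step between compound 2 and compound 4 cannot be read, because both compounds sit at a limit of the assay rather than at a number: the limit of > 50000 nM in this assay, at which 2 of the 4 values shown sit.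

The compounds shown leave open how an amine or a methoxy group in place of the hydroxyl would behave in this assay. They also leave open whether the change would act the same way on a core carrying a longer chain in place of trifluoromethoxy.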